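Adding fluoro to compound 3: what to expect

The source may report more compounds than this note shows. Statements on the series, on what has been measured and on what is new or still open speak of the compounds shown alone.

Values so far in a physicochemical assay for lipophilicity, read by HPLC, at pH 7.4 (on this read-out lower numbers stand for lower lipophilicity and higher numbers for higher lipophilicity), are these:
Compound 1 `Cc1c(F)cccc1C(=O)Nc1cc(Cl)ccn1` gives 2.3
Compound 2 `Cc1c(F)cccc1C(=O)Nc1ccccn1` gives 2.6
Compound 3 `Cc1ccnc(NC(=O)c2ccccc2C)c1` gives 2.8

Compound 3 at 2.8 stands beyond the scatter above compound 1 and within the scatter of compound 2. Compound 4 `Cc1ccnc(NC(=O)c2cccc(F)c2C)c1` has not yet been measured. The change is fluoro in place of hydrogen on an aromatic carbon and amounts to fluoro in place of hydrogen on an aromatic carbon, ortho to a methyl group. Going by the values given here, no measured step involves fluoro itself. The closest one, hydrogen in place of chloro on an aromatic carbon, is a number 0.30 log units higher from compound 1 to compound 2 (within the scatter) and so gives no firm direction. The expected change is therefore only a number 0.10 log units higher from compound 3 to compound 4 (within the scatter) and nothing beyond the scatter is expected. For compound 4 the estimate is 2.9 within an expected range of 2.6 to 3.2 on this reading.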

Compound 4, distribution coefficient: 3.5
Estimate against measurement, compound 4: 0.60 log units below; the measured number lies above the stated range.
By their numbers in this assay, from the lowest: compounds 1, 2 and 3 (each within the scatter of the next, the first and the last beyond it); then compound 4.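

In this assay, going by these compounds alone, fluoro in place of hydrogen on an aromatic carbon, ortho to a methyl group, gives the first reading for fluoro itself: a number 0.70 log units higher from compound 3 to compound 4 (beyond the scatter). The two methyl changes also end beyond the scatter, with methyl in place of hydrogen giving a number 0.90 log units higher from compound 2 to compound 4 (beyond the scatter) and methyl in place of chloro giving a number 1.20 log units higher from compound 1 to compound 4 (beyond the scatter). No evidence is available that would explain these steps.

On these data alone, it remains open whether an amine or a methoxy group at this position would shift the number as fluoro does. A step of this size for fluoro is also untested on a ring without the methyl group.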